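The compounds below may be only part of what the source reports. "The series", "measured", "known", "first", "only" and "open" are said of these compounds alone.

Three compounds built on one shared core were tested in a functional assay on 786-0 cells (Homo sapiens) for inhibition, read by sulforhodamine B assay, with a stated time of 48 h; a higher number here means a weaker inhibitor of growth, a lower number a stronger inhibitor of growth. Compound 1 `COc1ccc(-c2c(CNC(C)(C)C)c(C(=O)O)nn2-c2ccccc2)cc1` gave > 659000 nM, which is a limit of the assay rather than a number. Compound 2 `CC(C)(C)NCc1c(C(=O)O)nn(-c2ccccc2)c1-c1ccc([N+](=O)[O-])cc1` gave > 634000 nM, also a limit. Compound 3 `COc1ccc(-c2c(CNC(C)(C)C)c(C(=O)O)nn2-c2ccc(Cl)cc2)cc1` gave > 605000 nM, again a limit. Compound 2 differs from compound 1 by nitro in place of methoxy on an aromatic carbon, and the step that the two limits leave unreadable from compound 1 to compound 2 cannot be sized because compound 1 sits at the limit of > 659000 nM in this assay, at which 1 of the 3 values shown sits, and compound 2 sits at the limit of > 634000 nM in this assay, at which 1 of the 3 values shown sits. Compound 3 differs from compound 1 by chloro in place of hydrogen on an aromatic carbon, and the step that the two limits leave unreadable from compound 1 to compound 3 is likewise unreadable because compound 3 sits at the limit of > 605000 nM in this assay, at which 1 of the 3 values shown sits. Compound 4 `CC(C)(C)NCc1c(C(=O)O)nn(-c2ccc(Cl)cc2)c1-c1ccc([N+](=O)[O-])cc1` has not yet been measured; it differs from compound 3 by nitro in place of methoxy on an aromatic carbon, the same change as from compound 1 to compound 2, made at the same place. With every neighbour resting at a limit, compound 4 is expected to behave the same way, so the estimated step is a number no higher from compound 3 to compound 4 (the limit leaves the size open). The estimated value for compound 4 is therefore 600000 nM, between 150000 nM and 1000000 nM, most likely reported only as a limit.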

Compound 4, concentration for 50% growth inhibition: 104000 nM
Compound 4: the middle estimate sits 5.8-fold (0.76 log units) above what was measured, outside the stated range (below it).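

In this assay, nitro in place of methoxy on the chloro-bearing core gives an at least 5.8-fold lower number from compound 3 to compound 4 (0.76 log units; beyond the scatter), and chloro in place of hydrogen on the nitro-bearing core gives an at least 6.0-fold lower number from compound 2 to compound 4 (0.78 log units; beyond the scatter); compound 4, which carries both groups, is the only compound shown with a measured number rather than a limit. The same two changes made on the core of compound 1 run between limits and cannot be read, so the nitro change is sized on the chloro-bearing core only. This shows that the change can lower the number on one core, but not that its effect carries over unchanged, or fails to carry over, to the other core.

The compounds shown leave open whether another group, such as an amine or a nitrile, could do what nitro does at this place, and whether fluoro could replace chloro. They also leave open what a methyl ester in place of the carboxylic acid would do.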